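A few compounds are considered here, and "the series" means these few. Any claim that something is new, unique, unknown or untested is made for them only; others in the source may bear on it.

Three compounds share one core and differ only in the group on the benzyl ring bound to sulfur. Compound 1 `CC1=C(C(=O)Nc2ccc([N+](=O)[O-])cc2)C(c2ccc(Br)cc2)N=C(SCc2ccccc2)N1` gives 3.6% in a functional assay on the whole organism (artery, strain albino) with Rattus norvegicus as the target, with a stated time of 30 min, at a dose of 10 mg/kg by the oral route; on this read-out lower numbers stand for less inhibition and higher numbers for more inhibition at the one dose given (going by the name of the read-out). Compound 2 `CC1=C(C(=O)Nc2ccc([N+](=O)[O-])cc2)C(c2ccc(Br)cc2)N=C(SCc2ccccc2Cl)N1` gives 3.6% in this assay. Compound 3 `CC1=C(C(=O)Nc2ccc([N+](=O)[O-])cc2)C(c2ccc(Br)cc2)N=C(SCc2ccc(Cl)cc2)N1` gives 6.2% in this assay. Compound 3 has the highest of the three numbers, but the step of a number 2.6 percentage points higher from compound 1 to compound 3 (within the scatter) and the step of a number 2.6 percentage points higher from compound 2 to compound 3 (within the scatter) both lie within the scatter, so none of the three can be told apart.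

Compound 4 `CC1=C(C(=O)Nc2ccc([N+](=O)[O-])cc2)C(c2ccc(Br)cc2)N=C(SCc2ccc(F)cc2)N1` differs from compound 3 by fluoro in place of chloro on an aromatic carbon. Within the data shown here, no measured step swaps one halogen for another at this place; the nearest is a number 2.6 percentage points higher from compound 1 to compound 3 (within the scatter), which added chloro there and barely moved the number. The expected step of a number 1.2 percentage points lower from compound 3 to compound 4 (within the scatter) is therefore none beyond the scatter. Compound 4 is estimated at 5%, between 0% and 13%.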

Compound 4, a percentage reported as inhibition, in the whole organism at one dose (the size of the read-out at that dose, not a potency): 5.2%
Compound 4: the middle estimate sits 0.2 percentage points below what was measured; low and high end bracket the measured number.
By their numbers in this assay, from the lowest: compounds 1, 2, 4 and 3 (each within the scatter of the next).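

A second halogen at this place, fluoro in place of chloro, gives a number 1 percentage points lower from compound 3 to compound 4 (within the scatter) in this assay and so reads no differently from chloro. Fluoro in place of hydrogen gives a number 1.6 percentage points higher from compound 1 to compound 4 (within the scatter) while 4-fluorophenyl in place of 2-chlorophenyl gives a number 1.6 percentage points higher from compound 2 to compound 4 (within the scatter) and neither can be told from no change. Across these halogen swaps on the benzyl ring, the number stays flat.

Going by these compounds, whether an amine or a carboxylic acid on this ring carbon, or a longer chain on the sulfur, would move the number stays open. Nothing available gives a reason for these flat numbers.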